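A few compounds are considered here, and "the series" means these few. Any claim that something is new, unique, unknown or untested is made for them only; others in the source may bear on it.

Two compounds of the series have been run in a functional assay on cells for antagonist activity at prostaglandin D2 receptor 2 (Homo sapiens), read by flow cytometry, with a stated time of 10 min; on this read-out higher numbers stand for weaker inhibition and lower numbers for stronger inhibition. Compound 1 `CCCS(=O)(=O)c1ccc(F)c(C#Cc2cc(Cl)ccc2OCC(=O)O)c1` gives 23 nM. Compound 2 `Cc1ccc(S(=O)(=O)NC(C)C)cc1C#Cc1cc(Cl)ccc1OCC(=O)O` gives 250 nM, the higher of the two numbers, separated from compound 1 by a gap beyond the scatter. Compound 3 `Cc1ccc(S(C)(=O)=O)cc1C#Cc1cc(Cl)ccc1OCC(=O)O` is not yet measured and differs from compound 2 by methyl in place of isopropylamino on a sulfonyl sulfur. Among the compounds with values here, no measured pair shows this change, so the direction rests on the two numbers alone, where compound 1, carrying an alkylsulfonyl group, gives 23 nM. A move toward a lower number is expected, of roughly a 3.1-fold lower number from compound 2 to compound 3 (0.49 log units; beyond the scatter). Compound 3 is estimated at 80 nM, within 25 nM to 250 nM.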

Compound 3, half-maximal inhibitory concentration: 64 nM
Compound 3: middle estimate off by 1.3-fold (0.10 log units), on the high side; the range from low to high includes it.
By their numbers in this assay, from the lowest: compound 1; then compound 3; then compound 2.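

Within the data shown here, the change of isopropylamino to methyl on a sulfonyl sulfur gives the first one-place comparison in this assay, with a 3.9-fold lower number from compound 2 to compound 3 (0.59 log units; beyond the scatter). In this pair, the sulfonyl substituent alters the read-out, and the isopropylsulfamoyl group is not required for inhibition. Nothing available gives a reason for this step.

An isopropyl group or a plain amino group on the same sulfur would help separate the loss of nitrogen from the change in chain size. Longer alkyl chains on that sulfur also remain open.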